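Cyano to 1,3-benzothiazol-2-yl at the limit

This account rests on a few compounds, and the source may have more. Where it says the series, first, only, none or still open, it means among the compounds named here.

Measured so far in a toxicity assay on NIH3T3 cells (Mus musculus) for cytotoxicity, read by resazurin assay; a higher number here means that more compound is needed for the effect, a lower number that less compound is needed:
compound 1 `Nc1cc(-c2ccccc2)ccc1Cn1cncc1CNc1ccc(Cl)c(-c2ccccc2)c1`: > 1000 nM
compound 2 `N#Cc1ccc(NCc2cncn2Cc2ccc(-c3ccccc3)cc2)cc1-c1ccccc1`: > 1000 nM
compound 3 `N#Cc1ccc(NCc2cncn2Cc2ccc(-c3ccccc3)cc2N)cc1-c1ccccc1`: > 1000 nM

Compound 3 gives > 1000 nM here, and this is a limit, not a number. The series offers nothing else so far, with the limit of > 1000 nM in this assay, at which 3 of the 3 values shown sit, as its whole record.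

Compound 4 `Nc1cc(-c2ccccc2)ccc1Cn1cncc1CNc1ccc(-c2nc3ccccc3s2)c(-c2ccccc2)c1` carries 1,3-benzothiazol-2-yl in place of cyano on an aromatic carbon, ortho to a phenyl group, and 1,3-benzothiazol-2-yl in place of cyano on an aromatic carbon is the counted change.

Among the compounds with values here, two measured steps bear on this: a step that the two limits leave unreadable from compound 1 to compound 3 for cyano in place of chloro on an aromatic carbon, and a step that the two limits leave unreadable from compound 2 to compound 3 for amino in place of hydrogen on an aromatic carbon. Neither has a readable size, so neither gives a measure for the new group. In this assay no change beyond the scatter is expected, in either direction, and a further limit is the likeliest report. The estimated step is a step that the limit leaves unreadable from compound 3 to compound 4 on that expectation.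

For compound 4 the expected value is 1500 nM, with an estimated range from 600 nM to 4000 nM.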

Compound 4, half-maximal effective concentration: > 1000 nM
Compound 4: no number, only a limit (the forecaster's own chance of this, stated with the estimate: 75%); the middle value is on the limit's open side.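

In this assay compound 4 gives > 1000 nM, a limit and not a number. Compound 1 and compound 3 also stand at limits, so neither step to compound 4 can be read. The compounds shown leave open whether any of these group changes alters the concentration needed for the effect: the limit of > 1000 nM in this assay, at which 4 of the 4 values shown sit.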